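Acid-bearing side chain variation on the shared core

A few compounds are considered here, and "the series" means these few. Any claim that something is new, unique, unknown or untested is made for them only; others in the source may bear on it.

Measured compounds:
compound 1, `CC(C)c1onc(-c2c(Cl)cccc2Cl)c1COc1ccc(N(C)C(=O)c2cccc(C(=O)O)c2)c(C(F)(F)F)n1`, 537 nM
compound 2, `CC(C)c1onc(-c2c(Cl)cccc2Cl)c1COc1ccc(N(C)Cc2ccc(CCC(=O)O)cc2)c(C(F)(F)F)n1`, 16 nM
compound 3, `CC(C)c1onc(-c2c(Cl)cccc2Cl)c1COc1ccc(N(C)Cc2cccc(C(=O)O)c2)c(C(F)(F)F)n1`, 6 nM

In a functional assay on HEK293 cells for agonist activity at Bile acid receptor (Homo sapiens), read by a luciferase reporter (on this read-out higher numbers stand for an effect only at larger amounts of compound and lower numbers for an effect already at smaller amounts), compound 2 stands second highest of the three numbers, with a 2.7-fold lower number from compound 2 to compound 3 (0.43 log units; beyond the scatter) and a 34-fold lower number from compound 1 to compound 2 (1.53 log units; beyond the scatter) marking its distance to its neighbours. Compound 4, `CC(C)c1onc(-c2c(Cl)cccc2Cl)c1COc1ccc(N(C)Cc2ccc(C(=O)NS(C)(=O)=O)cc2)c(C(F)(F)F)n1`, carries the change ((methylsulfonyl)carbamoyl in place of 2-carboxyethyl on an aromatic carbon). Among the compounds with values here, no measured step exchanges the carboxylic acid for another group; the closest precedent is a 2.7-fold lower number from compound 2 to compound 3 (0.43 log units; beyond the scatter), a modest step from moving the acid within the benzyl part, while a 90-fold lower number from compound 1 to compound 3 (1.95 log units; beyond the scatter) concerns the linker to the nitrogen, not the acid. The expectation is therefore a step of at most modest size in this assay, in either direction, so a 1.6-fold higher number from compound 2 to compound 4 (0.19 log units; within the scatter) is the estimate. Compound 4 is expected to give about 25 nM, within 6 nM to 100 nM.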

Compound 4, half-maximal effective concentration: 11 nM
Estimate against measurement, compound 4: 2.3-fold (0.36 log units) above, and the stated range covers the measured number.
By their numbers in this assay, from the lowest: compounds 3, 4 and 2 (each within the scatter of the next, the first and the last beyond it); then compound 1.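

With (methylsulfonyl)carbamoyl in place of 2-carboxyethyl on this aromatic carbon, this assay shows a 1.5-fold lower number from compound 2 to compound 4 (0.16 log units; within the scatter), so the exchange leaves no readable change. Compounds 1, 2 and 3 all carry a carboxylic acid, whereas compound 4 has none and still gives 11 nM, so a carboxylic acid is not required here for activity at this level. Nothing at hand explains this result.

Open, as far as these compounds go, is whether a tetrazole or a primary amide at this place would also hold the number. Also open, from the compounds shown here alone, is whether (methylsulfonyl)carbamoyl in place of the carboxylic acid of compound 3 would hold its number.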